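Adding one methoxy to compound 1

The source may report more compounds than this note shows. Statements on the series, on what has been measured and on what is new or still open speak of the compounds shown alone.

In a functional assay on HeLa cells (Homo sapiens) for cytotoxicity, read by MTT assay, with a stated time of 24 h (a higher number here means a weaker inhibitor, a lower number a stronger inhibitor), compound 1 (`COc1cc(/C=C2\CN(C)C/C(=C\c3ccc(Cl)cc3Cl)C2=O)cc(OC)c1`) gives 7760 nM as the highest of three measured numbers. Compound 2 (`COc1cc(/C=C2\CN(C)C/C(=C\c3cccc([N+](=O)[O-])c3)C2=O)cc(OC)c1`) gives 2560 nM and compound 3 (`COc1cc(/C=C2\CN(C)C/C(=C\c3ccc(C#N)cc3)C2=O)cc(OC)c1`) gives 3420 nM in the same test. Compound 4 (`COc1cc(/C=C2\CN(C)C/C(=C\c3ccc(Cl)cc3Cl)C2=O)cc(OC)c1OC`) differs from compound 1 by methoxy in place of hydrogen on an aromatic carbon in one place: methoxy in place of hydrogen on an aromatic carbon, ortho to two methoxy groups and para to a large group. The measured steps change a different aryl group and never this site. Both a 3.0-fold lower number from compound 1 to compound 2 (0.48 log units; beyond the scatter) and a 2.3-fold lower number from compound 1 to compound 3 (0.36 log units; beyond the scatter) are modest, and a 1.3-fold higher number from compound 2 to compound 3 (0.13 log units; within the scatter) lies within the scatter. They set only a rough scale, so no step beyond the scatter is expected in this assay here. The expected change is a 1.3-fold lower number from compound 1 to compound 4 (0.11 log units; within the scatter) by this estimate. Compound 4 is estimated at 6000 nM with an expected range from 2600 nM to 12000 nM in this test.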

Compound 4, half-maximal inhibitory concentration: > 20000 nM
Compound 4 ended at the assay's limit (the forecaster's own chance of this, stated with the estimate: 3%); at least 3.3-fold (0.52 log units) between middle value and limit.
By their numbers in this assay, from the lowest: compounds 2 and 3 (each within the scatter of the next); then compound 1. At a limit, above all of these: compound 4.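

Compound 4 sits at a limit of the assay, which is not a number: the limit of > 20000 nM in this assay, at which 1 of the 4 values shown sits. The methoxy in place of hydrogen on an aromatic carbon, ortho to two methoxy groups and para to a large group, gives an at least 2.5-fold higher number from compound 1 to compound 4 (0.41 log units; beyond the scatter). Among these compounds, this site, which the earlier steps left untouched, therefore responds to substitution, and here the change goes toward a weaker inhibitor. The compounds shown leave open how a hydroxyl or an amine at this site would read. They also leave open whether this methoxy has the same effect alongside the 3-nitrophenyl of compound 2 or the 4-cyanophenyl of compound 3.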